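This account rests on a few compounds, and the source may have more. Where it says the series, first, only, none or still open, it means among the compounds named here.

Working notes on the series. In a functional assay on MCF7 cells (Homo sapiens) for cytotoxicity, read by MTT assay, with a stated time of 6 days (on this read-out lower numbers stand for an effect already at smaller amounts and higher numbers for an effect only at larger amounts of compound), compound 2 `COC(=O)c1c(-c2ccc(O)cc2)oc2ccccc2c1=O` gives > 25 ug/mL, which is a limit and not a number. Compound 1 `COC(=O)c1c(-c2ccc(OCc3ccccc3)cc2)oc2ccc(OC)cc2c1=O` gives > 25 ug/mL, again only a limit. All the data so far therefore come down to one observation: the limit of > 25 ug/mL in this assay, at which 2 of the 2 values shown sit. For the measured compounds named here, compound 2 has no numerical position, and no measured step is available to size a change against.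

Next in line is compound 3 `COC(=O)c1c(-c2ccc(O)cc2)oc2ccc(OC)cc2c1=O`, which differs from compound 2 by methoxy in place of hydrogen on an aromatic carbon, meta to a fused ring and para to a fused ring: methoxy in place of hydrogen on an aromatic carbon. No change beyond the usual scatter is expected in this assay, and no direction is favoured. That expectation rests on compound 1, which carries the same methoxy and reads > 25 ug/mL, also a limit. The estimated step that the limit leaves unreadable from compound 2 to compound 3 is accordingly treated as small. Another reading reported only as a limit is the likelier outcome. Compound 3 is expected at 30 ug/mL, with an estimated range of 12 ug/mL to 60 ug/mL.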

Compound 3, concentration for half-maximal effect: > 25 ug/mL
Compound 3 was reported as a limit; the forecaster's own chance of this, stated with the estimate: 75%; the middle value lies beyond the limit too.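

Compound 3 gives > 25 ug/mL in this assay, which is again a limit and not a number. No step can be read from compound 2 or compound 1 to compound 3: the limit of > 25 ug/mL in this assay, at which 3 of the 3 values shown sit.

The compounds shown leave open whether methoxy in place of hydrogen on an aromatic carbon, or hydrogen in place of benzyl on an oxygen on an aromatic ring, changes the read-out at all.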